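Acetyl in Place of Phenyl: What to Expect

The source may hold more compounds than are shown below. What is called first, only, known or untested is meant among the compounds shown, and "the series" means these compounds.

Two compounds share a cytotoxicity reading in an ADME assay on A549 cells (Homo sapiens) for cytotoxicity, read by MTT assay, with a stated time of 48 h; a lower number here means a stronger inhibitor, a higher number a weaker inhibitor. Compound 1 `Cc1nc2ccccc2cc1C(=O)n1nc(C)c(C2CCCCO2)c1C` gives 143 ug/mL in this assay. Compound 2 `COc1ccc(C2CC(c3cc4ccccc4nc3C)=NN2c2ccccc2)c(OC)c1OC` gives 143 ug/mL in this assay, level with compound 1 at the digits reported and within the usual scatter of it, and no order between the two can be read. Among the compounds with values here, no pair of measured compounds differing in one place is available here, and no measured step sets a scale for what a single change does in this assay.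

Compound 3 `COc1ccc(C2CC(c3cc4ccccc4nc3C)=NN2C(C)=O)c(OC)c1OC` is the unmeasured one. It differs from compound 2 in a single place: acetyl in place of phenyl on an amine nitrogen in a ring. Nothing measured here shows what such a change does to cytotoxicity. With compound 1 and compound 2 level in this assay, the plain expectation is that compound 3 lands near the same reading. The expected step, a 1.0-fold lower number from compound 2 to compound 3 (0.01 log units; within the scatter), is none beyond the scatter. Compound 3 is therefore estimated at 140 ug/mL, with a range from 70 ug/mL to 300 ug/mL.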

Compound 3, half-maximal inhibitory concentration: 86.5 ug/mL
For compound 3 the middle estimate is 1.6-fold (0.21 log units) above the measured one; the measured number falls inside the stated range.
By their numbers in this assay, from the lowest: compounds 3, 1 and 2 (each within the scatter of the next).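

Within the data shown here, this gives the first measured one-place step in this assay: acetyl in place of phenyl on an amine nitrogen in a ring gives a 1.7-fold lower number from compound 2 to compound 3 (0.22 log units; within the scatter), so the readings of these two compounds cannot be told apart. At this position, then, a six-membered aromatic ring of carbon only can give way to acetyl, a group with no ring and with one hydrogen-bond acceptor, without a change in the reading that stands clear of the scatter. Nothing available here explains the size of this step or says which part of the swap matters for cytotoxicity.

As far as these compounds go, one swap at this nitrogen sets only a first scale for the position and gives no trend, so it remains open whether a longer chain, such as butanoyl, or a group carrying an amine or a carboxylic acid would move the number beyond the scatter. From the compounds shown here alone, it is also open whether a plain hydrogen on this nitrogen would leave the reading level with those of compound 2 and compound 3.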